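A few compounds are considered here, and "the series" means these few. Any claim that something is new, unique, unknown or untested is made for them only; others in the source may bear on it.

Working notes on the series. Compound 1 `CCOC(=O)C1=C(C)NC(C)=C(C(=O)OCC)C1c1csc(-c2ccc(Cl)cc2)n1` gives 3650 nM in an assay on isolated protein for antagonist activity at Voltage-dependent L-type calcium channel subunit alpha-1C (Cavia porcellus), with a stated time of 15 min (on this read-out lower numbers stand for stronger inhibition and higher numbers for weaker inhibition), and stands at the lowest of the three numbers on hand. Compound 2 `CC1=C(C(=O)OC2CCCC2)C(c2csc(-c3ccc(Cl)cc3)n2)C(C(=O)OC2CCCC2)=C(C)N1` gives 19000 nM in this assay, a number beyond the scatter from compound 1. Compound 3 `CC1=C(C(=O)OCCc2ccccc2)C(c2csc(-c3ccc(Cl)cc3)n2)C(C(=O)OCCc2ccccc2)=C(C)N1` gives 500000 nM in this assay, further still from compound 1. Going by the values given here, no pair of measured compounds differs in one place only, so the values of compound 2 and compound 3 show nothing more than that these ester variants sit at weaker numbers than compound 1.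

Compound 4 `CCOC(=O)C1=C(C)NC(C)=C(C(=O)OC(C)(C)C)C1c1csc(-c2ccc(Cl)cc2)n1` has not yet been measured in this assay. It differs from compound 1 by tert-butyl in place of ethyl on an oxygen next to a carbonyl group. Among the compounds with values here, with no single-point step available, the expectation rests on the spread seen so far: compound 2 with 19000 nM and compound 3 with 500000 nM both fall weaker than compound 1, and compound 4 keeps one ethyl ester of compound 1 unchanged. A modest step toward weaker inhibition is expected from compound 1 to compound 4, a 1.5-fold higher number from compound 1 to compound 4 (0.18 log units; within the scatter), possibly no further than the scatter. Compound 4 is therefore estimated at 5500 nM in this assay, with a range from 1800 nM to 17000 nM.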

Compound 4, half-maximal inhibitory concentration: 91000 nM
Estimate against measurement, compound 4: 17-fold (1.22 log units) below, and the stated range ends below it.
By their numbers in this assay, from the lowest: compound 1; then compound 2; then compound 4; then compound 3.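

Going by these compounds alone, this is the first single-place comparison: in this assay, tert-butyl in place of ethyl on an oxygen next to a carbonyl group gives a 25-fold higher number from compound 1 to compound 4 (1.40 log units; beyond the scatter) while the remaining ethyl ester of compound 1 stays unchanged. The position is therefore far from indifferent to what sits on this ester oxygen, even though neither ethyl nor tert-butyl carries a ring, a hydrogen-bond donor or acceptor, or a net charge, and the two groups differ here only in carbon count and in the shape of the chain. No measurement on hand bears on the reason for the size of this step.

The compounds shown leave open whether an isopropyl or a straight butyl group on this oxygen would sit nearer compound 1 or nearer compound 4, and so whether branching or carbon count tracks with the step. Also open, on these data alone, is how a methyl ester, a carboxylic acid or an amide at this place would read out in this assay against the ethyl ester of compound 1.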